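The source may report more compounds than this note shows. Statements on the series, on what has been measured and on what is new or still open speak of the compounds shown alone.

Three compounds share one core and were examined in an assay on isolated protein for inhibition of DNA topoisomerase 1 (Homo sapiens), with a stated time of 30 min, tested at 20 uM; a lower number here means a weaker effect, a higher number a stronger effect of the compound at the concentration tested. Compound 1 `Oc1ccc(-c2cc(-c3cccs3)nc(-c3ccccc3Cl)c2)cc1` has no result in this assay: "not determined" (no result reported). Compound 2 `Oc1ccc(-c2cc(-c3cccc(Cl)c3)nc(-c3ccccn3)c2)cc1` gives 0% in this assay. Compound 3 `Oc1ccc(-c2cc(-c3ccc(Cl)cc3)nc(-c3cccs3)c2)cc1` gives 0% in this assay, which is level with compound 2 at the digits shown and thus within the usual scatter of repeated measurements; compound 1 contributes no number for comparison, so compound 2 is the only neighbour against which compound 3 can be set. Compound 4 `Oc1ccc(-c2cc(-c3cccc(Cl)c3)nc(-c3cccs3)c2)cc1` has not yet been measured. It differs from compound 3 in a single place, with the same atoms joined differently: 3-chlorophenyl in place of 4-chlorophenyl on an aromatic carbon. Among the measured compounds shown here, no step between two measured compounds that differ in one place exists in this set, so nothing shows directly how such a change shifts the read-out. Compound 2 and compound 3 both sit at the bottom of the scale, and a read-out that low leaves no signal from which a direction could be read. The expected step from compound 3 to compound 4 is no change at the digits printed from compound 3 to compound 4 (within the scatter), no change beyond the scatter. Compound 4 is estimated at 0%, within a range from 0% to 12%.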

Compound 4, a percentage reported as inhibition, at one concentration (the size of the read-out at that concentration, not a potency): 0%
Compound 4: the middle estimate sits on the measured number at the digits printed; the range from low to high includes it.
By their numbers in this assay, from the lowest: compounds 2, 3 and 4 (each within the scatter of the next).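

In this assay, among the compounds shown here, 3-chlorophenyl in place of 4-chlorophenyl on the aromatic carbon next to the ring nitrogen gives no change at the digits printed from compound 3 to compound 4 (within the scatter) and is the first change at this position that can be read directly. Thiophen-2-yl in place of pyridin-2-yl gives no change at the digits printed from compound 2 to compound 4 (within the scatter) in a second single-place comparison, which also links compound 2 to this pair. For the compounds shown here, both comparisons lie at the bottom of the scale, so they show only that neither change produces a measurable read-out at the concentration tested, not that the groups are interchangeable when the compound has an effect, and no measurement here explains the result.

The compounds shown leave open whether any group at this position can raise the read-out above the bottom of the scale, for example an amine or a carboxylic acid on the phenyl ring in place of the chlorine. The 2-chlorophenyl group of compound 1 also gives no comparison, since compound 1 has the entry "not determined" (no result reported) in this assay.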